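Cyclopropyl Replacement in a Fluorinated Histone Deacetylase 8 Series

The source may report more compounds than this note shows. Statements on the series, on what has been measured and on what is new or still open speak of the compounds shown alone.

Measured compounds:
compound 1 `CC(C)[C@@H](C(=O)Nc1ccc(C(=O)Nc2ccccc2N)cc1)c1ccccc1`: 38%
compound 2 `CC(C)(C(=O)Nc1ccc(C(=O)Nc2ccccc2N)cc1)c1ccccc1`: 0%
compound 3 `CC(C)[C@@H](C(=O)Nc1ccc(C(=O)Nc2ccc(F)cc2N)cc1)c1ccccc1`: 6%

All three were tested in an assay on isolated protein for inhibition of histone deacetylase 8 (Homo sapiens), read by fluorescence, tested at 1 uM; a higher number here means more inhibition at the concentration tested (going by the name of the read-out), a lower number less inhibition. Compound 3 stands second highest of the three numbers; its value lies within the scatter of compound 2, while the step of a number 32 percentage points lower from compound 1 to compound 3 (beyond the scatter) places it well below compound 1. Compound 4 `Nc1cc(F)ccc1NC(=O)c1ccc(NC(=O)C2CC2c2ccccc2)cc1` differs from compound 3 in one place: 2-phenylcyclopropyl in place of 2-methyl-1-phenylpropyl on a carbonyl carbon. Within the data shown here, no measured step covers an exchange on that carbonyl carbon; the only measured step, a number 32 percentage points lower from compound 1 to compound 3 (beyond the scatter), concerns the fluoro that compound 3 and compound 4 both carry, so compound 3 is the natural point of comparison. The expected step is a number 2 percentage points higher from compound 3 to compound 4 (within the scatter), which would stay within the scatter. Compound 4 is therefore estimated at 8%, with a range from 0% to 25%.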

Compound 4, a percentage reported as inhibition, at one concentration (the size of the read-out at that concentration, not a potency): 14%
The estimate for compound 4 lay 6 percentage points below the measured number, and the stated range covers the measured number.
By their numbers in this assay, from the lowest: compounds 2, 3 and 4 (each within the scatter of the next, the first and the last beyond it); then compound 1.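

This is the first change shown at the carbonyl carbon, and 2-phenylcyclopropyl in place of 2-methyl-1-phenylpropyl gives a number 8 percentage points higher from compound 3 to compound 4 (within the scatter) and so no change that can be told from scatter. With the fluoro present, this position therefore takes a ring-closed group in place of the branched chain without a clear gain or loss of inhibition. Nothing measured here explains this result.

The compounds shown leave open whether 2-phenylcyclopropyl would give the same result without the fluoro. They also leave open whether an amine or a longer chain on the carbonyl carbon would shift inhibition beyond the scatter.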